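Replacing 3-methoxyazetidin-1-yl with dimethylamino on a carbonyl carbon

The source may report more compounds than this note shows. Statements on the series, on what has been measured and on what is new or still open speak of the compounds shown alone.

In a functional assay on MDA-MB-231 cells (Homo sapiens) for inhibition, read by sulforhodamine B assay, with a stated time of 72 h (a higher number here means a weaker inhibitor of growth, a lower number a stronger inhibitor of growth), compound 1 (`CCOC(=O)/C=C/c1ccncc1-c1ccc2ccccc2c1`) gives 8090 nM and compound 2 (`CNC(=O)CCc1ccncc1-c1ccc2ccccc2c1`) gives 8980 nM as growth-inhibition concentrations. Compound 3 (`COC1CN(C(=O)/C=C/c2ccncc2-c2ccc3ccccc3c2)C1`) gives > 10000 nM in this assay and this is a limit of the assay, not a number. From the compounds shown here alone, compound 3 therefore stands at the limit of > 10000 nM in this assay, at which 1 of the 3 values shown sits, and its exact place is unknown.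

The next compound, compound 4 (`CN(C)C(=O)/C=C/c1ccncc1-c1ccc2ccccc2c1`), carries dimethylamino in place of 3-methoxyazetidin-1-yl on a carbonyl carbon and keeps the rest of the structure. For the measured compounds named here, two measured steps bear on this change. Putting 3-methoxyazetidin-1-yl in place of ethoxy on that carbonyl carbon gave an at least 1.2-fold higher number from compound 1 to compound 3 (0.09 log units; that floor lies within the scatter) and that figure is only a floor. Putting 2-(methylcarbamoyl)ethyl in place of 2-(ethoxycarbonyl)ethenyl gave a 1.1-fold higher number from compound 1 to compound 2 (0.05 log units; within the scatter) and so made no measurable difference. Neither step offers a reason to expect a large move in either direction. The change is expected to be small, estimated as an at least 1.1-fold lower number from compound 3 to compound 4 (0.04 log units; that floor lies within the scatter) and not beyond the scatter. A further reading at the limit would be no surprise. For compound 4 the expected value is 9000 nM in this assay and the estimated range runs from 4500 nM to 16000 nM for this measurement.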

Compound 4, concentration for 50% growth inhibition: 7990 nM
Beside the measured number, compound 4's estimate is 1.1-fold (0.05 log units) above it, within the range that was stated.
By their numbers in this assay, from the lowest: compounds 4, 1 and 2 (each within the scatter of the next). At a limit, above all of these: compound 3.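

With dimethylamino on the carbonyl carbon, compound 4 gives a measured number in this assay, and the two steps that can be compared directly both stay within the scatter: a 1.0-fold lower number from compound 1 to compound 4 (0.01 log units; within the scatter) for dimethylamino in place of ethoxy, and a 1.1-fold lower number from compound 2 to compound 4 (0.05 log units; within the scatter) for 2-(dimethylcarbamoyl)ethenyl in place of 2-(methylcarbamoyl)ethyl. Against 3-methoxyazetidin-1-yl the change reads only as a floor, an at least 1.2-fold lower number from compound 3 to compound 4 (0.09 log units; that floor lies within the scatter), so it does not show how far apart these two groups lie. Compound 3 remains at a limit of the assay, which is not a number: the limit of > 10000 nM in this assay, at which 1 of the 4 values shown sits.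

The compounds shown leave open whether any other group on this carbonyl carbon, such as a hydroxyl that would make a carboxylic acid or a longer chain ending in an amine, would move the number beyond the scatter. From the compounds shown here alone, the true place of compound 3 also stays open.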